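This account rests on a few compounds, and the source may have more. Where it says the series, first, only, none or still open, it means among the compounds named here.

Compound 1, with the structure `CO/N=C1\C[C@@H](c2ccc(Cl)cc2)N[C@@H](c2ccc(Cl)cc2)[C@@H]1C`, carries two 4-chlorophenyl groups on its core and is a weak inhibitor in a functional assay on HeLa cells (Homo sapiens) for inhibition, read by MTT assay, with a stated time of 24 h (a lower number here means a stronger inhibitor, a higher number a weaker inhibitor), where compound 1 gives 49000 nM. Compound 2, with the structure `CC[C@@H]1/C(=N/OC)C[C@@H](c2ccccc2)N[C@H]1c1ccccc1`, has a different core: how the two cores differ is not broken down here. In this assay compound 2 gives 57300 nM, a number that lies within the usual scatter of the number for compound 1, so the two compounds cannot be told apart on this read-out. Compound 3, with the structure `CO/N=C1\C[C@@H](c2ccc(Cl)cc2)N(C)[C@@H](c2ccc(Cl)cc2)[C@@H]1C`, differs from compound 1 by methyl in place of hydrogen on an amine nitrogen in a ring. In this assay compound 3 gives 36300 nM; the step of a 1.3-fold lower number from compound 1 to compound 3 (0.13 log units; within the scatter) is within the scatter, as is the gap between compound 3 and compound 2.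

Compound 4, with the structure `CC[C@@H]1/C(=N/OC)C[C@@H](c2ccccc2)N(C)[C@H]1c1ccccc1`, has not yet been measured. It differs from compound 2 by methyl in place of hydrogen on an amine nitrogen in a ring. This is the same kind of change as that from compound 1 to compound 3, but not the same: in compound 3 the ring atoms flanking the changed nitrogen each bear a 4-chlorophenyl group and the ring atom two bonds away bears a methyl group, while in compound 4 they each bear a phenyl group and that ring atom bears an ethyl group. Since the earlier step, from compound 1 to compound 3, stayed within the scatter, compound 4 is expected to show a step of about a 1.3-fold lower number from compound 2 to compound 4 (0.10 log units; within the scatter) in this assay, resting on the value of compound 2, 57300 nM. Compound 4 is therefore estimated to give about 45000 nM in this assay, with a range from 22000 nM to 95000 nM.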

Compound 4, half-maximal inhibitory concentration: 41700 nM
Beside the measured number, compound 4's estimate is 1.1-fold (0.03 log units) above it; the range from low to high includes it.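

In this assay, methyl in place of hydrogen on the amine nitrogen in the ring gives a 1.4-fold lower number from compound 2 to compound 4 (0.14 log units; within the scatter), and this step agrees with the one seen for the same change on the core of compound 1: the same change on two cores in this assay, a 1.3-fold lower number (0.13 log units; within the scatter) from compound 1 to compound 3 and a 1.4-fold lower number (0.14 log units; within the scatter) from compound 2 to compound 4, 1.0-fold (0.01 log units) apart, within the scatter of two such steps. This shows that, across these two cores, the change behaves alike: on neither core does it move the number by more than repeated measurements would, whether the flanking ring atoms each bear a 4-chlorophenyl group and the further ring atom a methyl group, or they each bear a phenyl group and that ring atom an ethyl group. It does not show a real gain from the methyl group that carries over from one core to the other, since both steps are too small to be read as effects, and two pairs cannot establish a rule for the series.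

The compounds shown leave open whether a larger group on the ring nitrogen, such as a benzyl or an acetyl group, would shift the number beyond the scatter. They also leave open whether the same change would stay as small on a core carrying other groups on its aromatic rings, such as methoxy or fluorine.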